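This account rests on a few compounds, and the source may have more. Where it says the series, first, only, none or still open, it means among the compounds named here.

Three compounds share one core and differ only in the group on the carbonyl carbon. Compound 1 `CN(C(=O)C(C)(C)C)c1ccc2[nH]c(-c3n[nH]c4ccccc34)cc2n1` carries a tert-butyl group there, and in a functional assay on A549 cells (Homo sapiens) for antiproliferative activity, read by MTT assay, with a stated time of 72 h (on this read-out lower numbers stand for stronger inhibition and higher numbers for weaker inhibition), compound 1 gives 24400 nM. Compound 2 `CN(C(=O)CCc1ccccc1)c1ccc2[nH]c(-c3n[nH]c4ccccc34)cc2n1` carries a phenethyl group, and in this assay compound 2 gives 18100 nM; the step of a 1.3-fold lower number from compound 1 to compound 2 (0.13 log units; within the scatter) stays within the scatter. Compound 3 `CN(C(=O)c1ccc(Br)cc1)c1ccc2[nH]c(-c3n[nH]c4ccccc34)cc2n1` carries a 4-bromophenyl group, and in this assay compound 3 gives 4250 nM, the lowest of the three numbers; the steps of a 5.7-fold lower number from compound 1 to compound 3 (0.76 log units; beyond the scatter) and a 4.3-fold lower number from compound 2 to compound 3 (0.63 log units; beyond the scatter) both lie beyond the scatter. Compound 4 `CN(c1ccc2[nH]c(-c3n[nH]c4ccccc34)cc2n1)S(=O)(=O)c1ccc(Br)cc1` keeps the 4-bromophenyl group and alters only its link to the nitrogen: (4-bromophenyl)sulfonyl in place of (4-bromophenyl)carbonyl on a nitrogen on an aromatic ring. Within the data shown here, none of the measured steps touches this link; all three vary only the group on the carbonyl carbon. The group that the steps of a 5.7-fold lower number from compound 1 to compound 3 (0.76 log units; beyond the scatter) and a 4.3-fold lower number from compound 2 to compound 3 (0.63 log units; beyond the scatter) point to is retained in compound 4, so compound 4 is expected to stay near compound 3 in this assay, with no step beyond the scatter foreseen but with little direct support. Compound 4 is therefore estimated at 6000 nM, between 1500 nM and 25000 nM, a step of a 1.4-fold higher number from compound 3 to compound 4 (0.15 log units; within the scatter).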

Compound 4, half-maximal inhibitory concentration: 19700 nM
Beside the measured number, compound 4's estimate is 3.3-fold (0.52 log units) below it, and the stated range covers the measured number.
By their numbers in this assay, from the lowest: compound 3; then compounds 2, 4 and 1 (each within the scatter of the next).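

The link that joins the 4-bromophenyl group to the nitrogen on an aromatic ring proves to matter as much as the group itself: in this assay the change from (4-bromophenyl)carbonyl to (4-bromophenyl)sulfonyl gives a 4.6-fold higher number from compound 3 to compound 4 (0.67 log units; beyond the scatter), so the advantage of compound 3 does not survive this change of link. With the sulfonyl link, the 4-bromophenyl group no longer stands apart from the phenethylcarbonyl and (tert-butyl)carbonyl groups, as a 1.1-fold higher number from compound 2 to compound 4 (0.04 log units; within the scatter) and a 1.2-fold lower number from compound 1 to compound 4 (0.09 log units; within the scatter) both show. The data shown offer no measurement that explains this difference between the two links.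

On these data alone, it remains open whether the bromine contributes to the result for compound 3, which a plain phenyl or a 4-aminophenyl group on the carbonyl carbon could test. As far as these compounds go, it also remains open how a methylsulfonyl group, or a urea link to the same 4-bromophenyl group, would behave at this nitrogen.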